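A few compounds are considered here, and "the series" means these few. Any claim that something is new, unique, unknown or untested is made for them only; others in the source may bear on it.

The compounds share the core of compound 1 `CCCCNC(=O)C1CC(=O)c2cc(O)c(OC)cc2O1`, a chromanone carrying a hydroxyl and a methoxy group and an amide at the saturated ring. In a functional assay (brain) for inhibition, with Rattus norvegicus as the target (a lower number here means a stronger inhibitor, a higher number a weaker inhibitor), compound 1 gives 177000 nM. Of the two numbers given in this assay, that of compound 1 is the highest. Compound 2 `COc1cc2c(cc1O)CCC(C(=O)Nc1ccc([N+](=O)[O-])cc1)O2` carries an anilide instead of an alkyl amide, and in this assay compound 2 gives 3800 nM, a much lower number than compound 1 and beyond the scatter. Compound 3 `COc1cc2c(cc1O)CCC(C(=O)O)O2` carries the free acid in place of the amide. For compound 3 this assay reports only a limit, > 300000 nM, not a number. One of the three values shown sits at the limit of > 300000 nM in this assay, at which 1 of the 3 values shown sits.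

Compound 4 `CCCNC(=O)C1CC(=O)c2cc(O)c(OC)cc2O1` has not yet been measured in this assay. It differs from compound 1 by hydrogen in place of methyl on a saturated chain carbon, three bonds along the chain from an amide-type nitrogen. No pair of measured compounds shows a step of this kind, so there is nothing among the shown values to set its size. Such a small change at the chain is expected to move the number little, if at all, beyond the scatter, in either direction. Compound 4 is therefore expected to give about 200000 nM in this assay, within a range from 90000 nM to 400000 nM, which means an expected step of a 1.1-fold higher number from compound 1 to compound 4 (0.05 log units; within the scatter).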

Compound 4, half-maximal inhibitory concentration: > 300000 nM
Compound 4 gave a limit, no number; the forecaster's own chance of this, stated with the estimate: 25%; at least 1.5-fold (0.17 log units) between middle value and limit.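

Shortening the butyl chain of compound 1 to the propyl chain of compound 4 gives the first step at this place on the amide chain, and it can be stated only as a floor: an at least 1.6-fold higher number from compound 1 to compound 4 (0.22 log units; that floor lies within the scatter). That floor lies within the scatter, so the result does not establish that removing this one methyl weakens inhibition in this assay, although it does show that the propyl amide gives no number lower than that of the butyl amide. With compound 4 at its limit, which is not a number, the alkyl amide series has reached the top of the range that can be read here, and two values now stand there: the limit of > 300000 nM in this assay, at which 2 of the 4 values shown sit.

As far as these compounds go, the true size of the step remains open, as does the question of whether a longer chain than butyl on the amide nitrogen would give a lower number than compound 1. Also open, from the compounds shown here alone, is whether an amine or a carboxylic acid at the end of the butyl chain would shift the number, and compound 2 cannot settle this, as it differs from compound 1 in more than one place.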